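The source may report more compounds than this note shows. Statements on the series, on what has been measured and on what is new or still open speak of the compounds shown alone.

Within the data shown here, in a functional assay on MDA-MB-231 cells (Homo sapiens) for antiproliferative activity, read by MTT assay, with a stated time of 72 h (on this read-out lower numbers stand for stronger inhibition and higher numbers for weaker inhibition), only two related compounds have been tested so far. For compound 1 `CC1=CC[C@H]2[C@@H]1CC=C(C)[C@@H](CCC1=C(C)CC[C@@H]3OC(C)(C)[C@@H](O)CC[C@@]13C)C2(C)C`, the test returned only a limit, > 50000 nM, and not an actual number. Among the measured compounds shown here, compound 2 `CC1=CC[C@H]2[C@H](CC[C@]2(C)O)C(C)(C)[C@@H]1CC[C@H]1[C@]2(C)CC[C@H](OC(=O)c3ccccc3)C(C)(C)O[C@H]2CC[C@@]1(C)O` gives 16100 nM, which makes it the only compound here with a true measured value. Compound 3 `CC1=CC[C@H]2[C@H](CC[C@]2(C)O)C(C)(C)[C@@H]1CC[C@H]1[C@]2(C)CC[C@H](OCc3ccccc3)C(C)(C)O[C@H]2CC[C@@]1(C)O` differs from compound 2 in one place: benzyl in place of benzoyl on an oxygen on a saturated carbon. Apart from this, the rest of the structure stays the same. For the measured compounds named here, no measured pair shows what this swap does, so the expectation is cautious: no change beyond the usual scatter of this assay, in either direction. The expected move is small, a 1.2-fold higher number from compound 2 to compound 3 (0.09 log units; within the scatter). For compound 3 the estimated value is 20000 nM, with an expected range from 8000 nM to 45000 nM.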

Compound 3, half-maximal inhibitory concentration: 29100 nM
Compound 3: the middle estimate sits 1.5-fold (0.16 log units) below what was measured; measured number inside the range.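

In this assay, among these compounds, the only step at this position is a 1.8-fold higher number from compound 2 to compound 3 (0.26 log units; within the scatter), so on this pair the benzoyloxy group can give way to benzyloxy without a change that can be told apart from the scatter. The carbonyl and its hydrogen-bond acceptor leave with the benzoyl group, and for this pair their loss does not show up as a clear change in the read-out. Nothing shown gives a cause for this result or a measured role for that carbonyl.

The compounds shown leave open whether the aromatic ring is needed at this oxygen, since both groups carry the same ring. They also leave open whether an amine, a carboxylic acid or a longer alkyl chain in the same place would move the number beyond the scatter.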